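The compounds below may be only part of what the source reports. "The series", "measured", "known", "first", "only" and "open" are said of these compounds alone.

Compound 1 `COCCCCCCCCCCCCCCC/C=C1\CC(CO)(COC(=O)C(C)(C)C)OC1=O` is the starting point. Going by the values given here, in a functional assay on MOLT-4F cells (Homo sapiens) for antiproliferative activity (on this read-out higher numbers stand for weaker inhibition of growth and lower numbers for stronger inhibition of growth), compound 1 gives 0.498 ug/mL, the lowest of the three numbers measured so far. Compound 2 `CCCCCOCCCCCCC/C=C1\CC(CO)(COC(=O)C(C)(C)C)OC1=O` gives 1.03 ug/mL in this assay, and the step of a 2.1-fold higher number from compound 1 to compound 2 (0.32 log units; beyond the scatter) is modest. Among the compounds with values here, compound 3 `COCCCCCCCCCCCCCCC/C=C1/CC(CO)(COC(=O)C(C)(C)C)OC1=O` gives 1.64 ug/mL, and the step of a 3.3-fold higher number from compound 1 to compound 3 (0.52 log units; beyond the scatter) is also modest; the only evidence bearing on it is the fact that one of compounds 1 and 3 is drawn with a defined configuration and the other without, at the place where they differ.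

The new compound 4 `CC(C)(C)C(=O)OCCCCCCCCCCCCCCC/C=C1\CC(CO)(COC(=O)C(C)(C)C)OC1=O` differs from compound 1 in one place: (tert-butyl)carbonyl in place of methyl on an oxygen on a saturated carbon. Neither measured step repeats this change. The closest is the step from compound 1 to compound 2, which also replaces the methoxy-bearing part of the long chain and gave only a modest weakening; the step to compound 3 concerns the double bond and does not bear on this change. A modest step, most likely toward a higher number, is therefore expected, so compound 4 is estimated at 0.9 ug/mL, within 0.3 ug/mL to 2.7 ug/mL, which is expected to mean a 1.8-fold higher number from compound 1 to compound 4 (0.26 log units; within the scatter).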

Compound 4, concentration for 50% growth inhibition: 0.605 ug/mL
Beside the measured number, compound 4's estimate is 1.5-fold (0.17 log units) above it; low and high end bracket the measured number.
By their numbers in this assay, from the lowest: compounds 1, 4, 2 and 3 (each within the scatter of the next, the first and the last beyond it).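

In this assay, the step with (tert-butyl)carbonyl in place of methyl on an oxygen on a saturated carbon is a 1.2-fold higher number from compound 1 to compound 4 (0.08 log units; within the scatter), so the two numbers cannot be told apart. The earlier compounds shown here gave no reading of this place, and here a group of 6 heavy atoms, including a carbonyl, stands where a methyl of 1 heavy atom stood, with no step beyond the scatter. Nothing given here explains why so large a replacement produces so small a step.

As far as these compounds go, whether an amine or a carboxylic acid on this chain would also stay within the scatter of compound 1 remains open. So does whether (tert-butyl)carbonyl would give a similar result on a shorter chain, or with the double bond drawn as in compound 3.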